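The compounds below may be only part of what the source reports. "The series", "measured", "known", "first", "only" and "open" are said of these compounds alone.

Measured compounds:
compound 1 `O=C(NCc1ccc(C(=O)N2CCCCc3ccccc32)c(F)c1)Nc1c(F)cccc1F`, 180 nM
compound 2 `CCc1cc(C(=O)N2CCCCc3ccccc32)ccc1CNC(=O)Nc1c(F)cccc1F`, 10 nM
compound 3 `CCOC(=O)CNC(=O)NCc1ccc(C(=O)N2CCCCc3ccccc32)cc1C`, 140 nM

All three were tested in a functional assay on HEK293 cells for agonist activity at Vasopressin V2 receptor (Homo sapiens), read by a luciferase reporter and cAMP accumulation; a lower number here means that less compound is needed, a higher number that more compound is needed for the effect. Among them compound 3 with 140 nM carries the second highest number; compound 1 lies so close that the two cannot be told apart, whereas compound 2 needs a far smaller amount, and that gap is a real one. Compound 4 `CCN(CC)C(=O)[C@@H]1CCCN1C(=O)NCc1ccc(C(=O)N2CCCCc3ccccc32)cc1C` has not yet been tested. It differs from compound 3 in a single place: 2-(diethylcarbamoyl)pyrrolidin-1-yl in place of ((ethoxycarbonyl)methyl)amino on a carbonyl carbon. Going by the values given here, no tested pair shows this exact change, so its effect has to be judged without a direct precedent. The step from compound 3 to compound 4 is expected to be small, perhaps a modest move toward a lower number, a 1.8-fold lower number from compound 3 to compound 4 (0.24 log units; within the scatter). Compound 4 is therefore estimated at 80 nM, with a likely range from 20 nM to 320 nM.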

Compound 4, half-maximal effective concentration: 350 nM
The estimate for compound 4 lay 4.4-fold (0.64 log units) below the measured number; the measured number lies above the stated range.
By their numbers in this assay, from the lowest: compound 2; then compounds 3, 1 and 4 (each within the scatter of the next, the first and the last beyond it).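

In this assay, going by these compounds alone, the change on this carbonyl carbon gives a 2.5-fold higher number from compound 3 to compound 4 (0.40 log units; beyond the scatter) and so shows that the group here affects the result, which the earlier compounds could not show. The entering 2-(diethylcarbamoyl)pyrrolidin-1-yl differs at once in size, ring, stereocentre and hydrogen-bond donor count, so this one step cannot say which difference matters. No available evidence explains the step.

Still open, from the compounds shown here alone, is whether an unsubstituted pyrrolidine, the opposite stereocentre or a carboxylic acid in place of the ethyl ester would behave differently.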